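Adding a methylamino group to a weak GPR39 agonist

The source may report more compounds than this note shows. Statements on the series, on what has been measured and on what is new or still open speak of the compounds shown alone.

Compound 1 `c1ccc(-c2cc(NCC3CC3)ncn2)nc1` gives 22000 nM
Compound 2 `CNc1nc(NCc2ccc(NC(C)=O)cc2)cc(-c2ccccn2)n1` gives 5 nM
Compound 3 `Cc1nc(NCc2ccc(Cl)cc2)cc(-c2ccccn2)n1` gives 81 nM

These three compounds were tested in a functional assay on HEK293 cells for agonist activity at G-protein coupled receptor 39 (Homo sapiens), read by inositol phosphate accumulation; on this read-out lower numbers stand for an effect already at smaller amounts and higher numbers for an effect only at larger amounts of compound. Compound 1 stands at the highest number of the three, far from both others: compound 3 lies at a much lower number, and compound 2 lower still, both differences well beyond the usual scatter. Compound 1 is therefore the weakest of the set.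

Compound 4 `CNc1nc(NCC2CC2)cc(-c2ccccn2)n1` has not yet been measured. It differs from compound 1 in one place: methylamino in place of hydrogen on an aromatic carbon. The shared core of compound 1 keeps its (cyclopropylmethyl)amino group and its pyridin-2-yl group; only the hydrogen between two ring nitrogen atoms gives way to methylamino.

Within the data shown here, no directly comparable step between two measured compounds is available, so the effect of this change has to be estimated. The expectation is a move toward smaller amounts, because compound 2 gives 5 nM and compound 3 gives 81 nM, both far below compound 1. The estimate for compound 4 is 400 nM, with a range from 40 nM to 4000 nM. This corresponds to an expected step of a 55-fold lower number from compound 1 to compound 4 (1.74 log units; beyond the scatter).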

Compound 4, half-maximal effective concentration: 164 nM
Beside the measured number, compound 4's estimate is 2.4-fold (0.39 log units) above it; the range from low to high includes it.
By their numbers in this assay, from the lowest: compound 2; then compound 3; then compound 4; then compound 1.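

Among these compounds, this pair gives the first direct reading of the ring position between two ring nitrogen atoms. In this assay, methylamino in place of hydrogen on this aromatic carbon gives a 130-fold lower number from compound 1 to compound 4 (2.13 log units; beyond the scatter), while the (cyclopropylmethyl)amino group and the pyridin-2-yl group stay the same. Compounds 1, 2 and 3 differ from one another in more than one place, so they could not tie a change in number to this position alone, whereas this large step belongs to this single change. No measurement shown here explains how the methylamino group produces the step.

The compounds shown leave open whether a plain amino group, a dimethylamino group or an ethylamino group in this place would give a step of similar size. From the compounds shown here alone, it also remains open whether methylamino in place of hydrogen would give a step of this size when a group other than (cyclopropylmethyl)amino is present on the shared core.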